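The compounds below may be only part of what the source reports. "The series", "measured", "known", "first", "only" and "open" are said of these compounds alone.

Measured in a physicochemical assay for lipophilicity, measured as octanol-water partition, at pH 7.4; a higher number here means a more lipophilic compound, a lower number a more polar compound:
- Compound 1 `Cc1cccc(C)c1-c1cccc(COc2ccc3c(c2)OCC3CC(=O)O)c1`: 3.88
- Compound 2 `O=C(O)CC1COc2cc(OCc3cccc(-c4csc5ccccc45)c3)ccc21`: 3.99

Among the compounds with values here, compound 1 and compound 2 are the only measured compounds, and their values lie within the scatter of each other. Compound 3 `COc1ccc(COc2ccc3c(c2)OCC3CC(=O)O)cc1-c1c(C)cccc1C` is still unmeasured. It derives from compound 1 through (methoxy in place of hydrogen on an aromatic carbon), with methoxy in place of hydrogen on an aromatic carbon, ortho to a 2,6-dimethylphenyl group and para to a large group.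

Within the data shown here, the only measured step, a number 0.11 log units higher from compound 1 to compound 2 (within the scatter), has 1-benzothiophen-3-yl in place of 2,6-dimethylphenyl on an aromatic carbon. It involves no methoxy and a different place, so it bears on this change only loosely. No step beyond the scatter is therefore expected in this assay, and no direction can be expected from these data. The expected change is a number 0.02 log units higher from compound 1 to compound 3 (within the scatter). For compound 3 the estimated value is 3.9, with an expected range from 3.6 to 4.2.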

Compound 3, distribution coefficient: 3.31
Compound 3: the middle estimate sits 0.59 log units above what was measured; measured number below the stated range.
By their numbers in this assay, from the lowest: compound 3; then compounds 1 and 2 (each within the scatter of the next).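

In this assay, adding methoxy in place of hydrogen on an aromatic carbon, ortho to a 2,6-dimethylphenyl group and para to a large group, gives a number 0.57 log units lower from compound 1 to compound 3 (beyond the scatter). The earlier pair had shown only an exchange of the 2,6-dimethylphenyl group with no step beyond the scatter, so this is the first sign that a change at this place can move the number, and here a single methoxy moves it downward. Nothing measured here accounts for the size or direction of this step.

As far as these compounds go, it remains open whether the step belongs to methoxy itself or would also follow from another group at this place, such as hydroxyl, fluorine or ethoxy. Also open, from the compounds shown here alone, is whether methoxy would give a similar step at another place on this ring, or alongside the 1-benzothiophen-3-yl group of compound 2.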